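Replacing the aryl group of a weak trifluoromethyl compound

A few compounds are considered here, and "the series" means these few. Any claim that something is new, unique, unknown or untested is made for them only; others in the source may bear on it.

Measured so far:
Compound 1 `COc1cc(-c2ccnc3cc(-c4ccc(C)cc4)nn23)cc(OC)c1OC`: 21 nM
Compound 2 `COc1cc(-c2ccnc3cc(-c4ccc(C(F)(F)F)cc4)nn23)cc(OC)c1OC`: 1840 nM

Both values come from a functional assay on HeLa cells (Homo sapiens) for inhibition, read by CCK-8 assay, with a stated time of 48 h; a higher number here means a weaker inhibitor, a lower number a stronger inhibitor. Compound 2 has the higher number of the two, which makes it the weaker inhibitor. The gap is large and lies beyond the usual scatter: an 88-fold higher number from compound 1 to compound 2 (1.94 log units; beyond the scatter). This single measured step comes from trifluoromethyl in place of methyl on an aromatic carbon.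

The next compound, compound 3 `COc1cc(-c2ccnc3cc(-c4cn(C)c5ccccc45)nn23)cc(OC)c1OC`, has not been measured yet. It keeps the shared core, but 1-methyl-1H-indol-3-yl stands in place of 4-(trifluoromethyl)phenyl on an aromatic carbon: 1-methyl-1H-indol-3-yl in place of 4-(trifluoromethyl)phenyl on an aromatic carbon. For the measured compounds named here, no measured compound carries this new group, so the evidence is indirect. Still, the step of an 88-fold higher number from compound 1 to compound 2 (1.94 log units; beyond the scatter) shows that a change in this group alone can move the number a long way, and compound 3 no longer has the trifluoromethyl group. A large drop is therefore expected, towards a stronger inhibitor, though probably not all the way to the level of compound 1: a 20-fold lower number from compound 2 to compound 3 (1.31 log units; beyond the scatter). The estimated value for compound 3 is 90 nM, with an expected range of 15 nM to 600 nM.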

Compound 3, half-maximal inhibitory concentration: 399 nM
The estimate for compound 3 lay 4.4-fold (0.65 log units) below the measured number; the measured number falls inside the stated range.
By their numbers in this assay, from the lowest: compound 1; then compound 3; then compound 2.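

In this assay, replacing 4-(trifluoromethyl)phenyl with 1-methyl-1H-indol-3-yl gives a 4.6-fold lower number from compound 2 to compound 3 (0.66 log units; beyond the scatter), so exchanging the whole aryl group for one with the same count of 10 heavy atoms, a second aromatic ring and a ring nitrogen restores only part of the lost activity. Replacing 4-methylphenyl with the same indole group gives a 19-fold higher number from compound 1 to compound 3 (1.28 log units; beyond the scatter), which leaves 4-methylphenyl with the lowest number of the three groups tested at this position and shows that this position responds to the whole aryl group, not only to the small substituent varied in the earlier pair. The data shown include no measurement that explains these differences between the three groups.

From the compounds shown here alone, it remains open how a plain phenyl, a 4-methoxyphenyl or a 4-aminophenyl group would compare at this position, and whether any of them could match 4-methylphenyl. Also open, going by these compounds, is what the methyl on the indole nitrogen contributes, which a 1H-indol-3-yl group, with hydrogen in its place, would begin to answer.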